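Aryl variation on a fused core: cytotoxicity working notes

The source may report more compounds than this note shows. Statements on the series, on what has been measured and on what is new or still open speak of the compounds shown alone.

Measured so far in a functional assay on Ehrlich cells (Mus musculus) for cytotoxicity, tested at 25 ug/mL; on this read-out higher numbers stand for a stronger effect at the one concentration tested and lower numbers for a weaker effect:
- compound 1 `COc1cc(N2C(N)=C(C#N)C(c3ccc(OC)c4ccccc34)C3=C2CC(C)(C)CC3=O)cc(OC)c1OC` gives 30%
- compound 2 `COc1cc(N2C(N)=C(C#N)C(c3cccc([N+](=O)[O-])c3)C3=C2CC(C)(C)CC3=O)cc(OC)c1OC` gives 20%
- compound 3 `COc1cc(N2C(N)=C(C#N)C(c3ccccc3Cl)C3=C2CC(C)(C)CC3=O)cc(OC)c1OC` gives 15%

Compound 3 gives the smallest of the three numbers. Its separation from compound 2 is within the scatter, a number 5 percentage points lower from compound 2 to compound 3 (within the scatter), while its separation from compound 1 is beyond it, a number 15 percentage points lower from compound 1 to compound 3 (beyond the scatter). The step of a number 10 percentage points lower from compound 1 to compound 2 (within the scatter) is within the scatter. All three steps are exchanges of the aryl group on the same saturated ring carbon, and only one of them exceeds the scatter.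

Compound 4 `COc1cc(N2C(N)=C(C#N)C(c3ccc(O)cc3)C3=C2CC(C)(C)CC3=O)cc(OC)c1OC` is not yet measured. The change is 4-hydroxyphenyl in place of 2-chlorophenyl on a saturated ring carbon. For the measured compounds named here, the steps that bear on it are the aryl exchanges above, which range from within the scatter to a modest loss. For this assay a change of that size is expected, with direction uncertain, so compound 4 is estimated to sit close to compound 3, with the step of a number 5 percentage points higher from compound 3 to compound 4 (within the scatter) expected to stay within the scatter. Compound 4 is estimated at 20%, with a range from 5% to 35%.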

Compound 4, a percentage reported as activity, at one concentration (the size of the read-out at that concentration, not a potency): 20%
Estimate against measurement, compound 4: no gap at the digits printed, within the range that was stated.
By their numbers in this assay, from the lowest: compounds 3, 2, 4 and 1 (each within the scatter of the next, the first and the last beyond it).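

In this assay, 4-hydroxyphenyl brings to this saturated ring carbon a hydrogen-bond donor and acceptor that 2-chlorophenyl lacks, yet the exchange gives a number 5 percentage points higher from compound 3 to compound 4 (within the scatter) and so does not separate the two groups, while the exchange for 3-nitrophenyl gives no change at the digits printed from compound 2 to compound 4 (within the scatter) and likewise leaves the two groups unseparated. Against the larger 4-methoxynaphthalen-1-yl group the result is a number 10 percentage points lower from compound 1 to compound 4 (within the scatter) as well, so the exchange from compound 1 to compound 3 remains the only aryl step here beyond the scatter, and the compounds shown offer no measured basis for explaining any of these steps.

Open, on these data alone, is whether an amine or a carboxylic acid on the phenyl ring would give a step beyond the scatter. Also open, as far as these compounds go, is how a longer alkyl chain in place of the aryl group on this carbon would read out.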